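Dimethylamino for Cyclopentylamino: Expected Liver Clearance

The compounds below may be only part of what the source reports. "The series", "measured", "known", "first", "only" and "open" are said of these compounds alone.

Measured compounds:
compound 1, `O=C1CCCN1CCCSc1nc2cc(Cl)ccc2o1`, 51 mL/min/g
compound 2, `O=C(CCSc1nc2cc(Cl)ccc2o1)NC1CCCC1`, "not determined" (no result reported)
compound 3, `O=C(CCSc1nc2cccc(Cl)c2o1)N1CCCC1`, 122 mL/min/g

Three compounds share a core and a sulfur-linked side chain, and were run in an ADME assay on microsomes from liver (Mus musculus) for metabolic stability, read by LC-MS, using NADPH, with a stated time of 45 min, tested at 0.5 uM; a higher number here means faster removal of the compound, a lower number slower removal. Compound 1 gives 51 mL/min/g in this assay. Compound 3 gives 122 mL/min/g in this assay. These two numbers lie within the usual scatter of repeated measurements of this kind, so neither can be called the faster or slower of the pair on this evidence. Compound 2, which carries the cyclopentylamino group, stands in this assay at "not determined" (no result reported), so its own standing cannot be read off and the step to compound 4 cannot be measured directly.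

Compound 4, `CN(C)C(=O)CCSc1nc2cc(Cl)ccc2o1`, differs from compound 2 in one place: dimethylamino in place of cyclopentylamino on a carbonyl carbon. Among the measured compounds shown here, with no step of this kind among the measured compounds, the reasonable expectation for compound 4 in this assay is a value of the same general size as compound 1 and compound 3 show, with no direction that can be called beyond the scatter. Compound 4 is therefore expected to give about 80 mL/min/g in this assay, estimated to fall between 30 mL/min/g and 200 mL/min/g.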

Compound 4, intrinsic clearance in a liver preparation (reported as CLH), per the amount of preparation that the assay uses: 41.8 mL/min/g
Compound 4: the middle estimate sits 1.9-fold (0.28 log units) above what was measured; the range from low to high includes it.
By their numbers in this assay, from the lowest: compounds 4 and 1 (each within the scatter of the next); then compound 3.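

In this assay, among the compounds shown here, compound 2 stands at "not determined" (no result reported) and compound 4 gives 41.8 mL/min/g with no step between them that can be read. The compounds shown leave open whether dimethylamino in place of cyclopentylamino changes clearance at all. No measured evidence here bears on the value of compound 4.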